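This account rests on a few compounds, and the source may have more. Where it says the series, first, only, none or still open, it means among the compounds named here.

Compound 1 `O=C1O[C@@H](CO)CN1c1ccc(-n2cc(-c3ccccn3)cn2)c(F)c1`: 59 ug/mL
Compound 2 `CN1CCN(C[C@H]2CN(c3ccc(-n4cc(-c5ccccn5)cn4)c(F)c3)C(=O)O2)CC1`: 70 ug/mL
Compound 3 `O=C(OC[C@H]1CN(c2ccc(-n3cc(-c4ccccn4)cn3)c(F)c2)C(=O)O1)c1ccccc1`: > 400 ug/mL, a limit of the assay

In an ADME assay on L02 cells (Homo sapiens) for cytotoxicity, read by MTT assay, with a stated time of 48 h (a lower number here means a stronger inhibitor, a higher number a weaker inhibitor), compound 2 gives 70 ug/mL, the highest of the two numbers, with compound 1 nearest at a 1.2-fold higher number from compound 1 to compound 2 (0.07 log units; within the scatter). Compound 3 reached only a limit, (the limit of > 400 ug/mL in this assay, at which 1 of the 3 values shown sits). Compound 4 `O=C1O[C@@H](Cn2ccnn2)CN1c1ccc(-n2cc(-c3ccccn3)cn2)c(F)c1` differs from compound 2 by 1H-1,2,3-triazol-1-yl in place of 4-methylpiperazin-1-yl on a saturated chain carbon bound to a saturated ring carbon. Going by the values given here, two steps bear on this position: the change from compound 1 to compound 2 gave a 1.2-fold higher number from compound 1 to compound 2 (0.07 log units; within the scatter), and the change from compound 2 to compound 3 gave an at least 5.7-fold higher number from compound 2 to compound 3 (0.75 log units; beyond the scatter). Swapping one ring for another at this carbon is expected to give no step beyond the scatter, no change at the digits printed from compound 2 to compound 4 (within the scatter). Compound 4 is expected to give 70 ug/mL, between 35 ug/mL and 160 ug/mL.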

Compound 4, half-maximal inhibitory concentration: 49 ug/mL
The estimate for compound 4 lay 1.4-fold (0.15 log units) above the measured number; measured number inside the range.
By their numbers in this assay, from the lowest: compounds 4, 1 and 2 (each within the scatter of the next). At a limit, above all of these: compound 3.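

In this assay there is a 1.4-fold lower number from compound 2 to compound 4 (0.15 log units; within the scatter) and a 1.2-fold lower number from compound 1 to compound 4 (0.08 log units; within the scatter) at this saturated chain carbon, so an aromatic five-membered ring reads here like 4-methylpiperazin-1-yl and hydroxy. Only benzoyloxy stands apart, with an at least 8.1-fold lower number from compound 3 to compound 4 (0.91 log units; beyond the scatter) in this comparison. Compound 3 sits at a limit of the assay, not at a number. From the compounds shown here alone, whether a carboxylic acid, a primary amine or a longer chain at this carbon would stay level with compound 1, compound 2 and compound 4 remains open, as does whether an acetyl ester would behave like benzoyloxy.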